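From Methyl to Fluoro on the Benzyl Ring

The compounds below may be only part of what the source reports. "The series", "measured", "known", "first", "only" and "open" are said of these compounds alone.

Compound 1 `O=c1ccoc2cc(OCc3cn(Cc4ccccc4)nn3)ccc12` in a functional assay on A549 cells (Homo sapiens) for cytotoxicity, read by MTT assay, with a stated time of 48 h (a lower number here means a stronger inhibitor, a higher number a weaker inhibitor), gives only a limit of the assay, > 100000 nM. Compound 2 `Cc1cccc(Cn2cc(COc3ccc4c(=O)ccoc4c3)nn2)c1` in this assay gives 20300 nM.

Compound 2 therefore holds the only number shown; the other value is a limit. Within the data shown here, the one measured step, methyl in place of hydrogen on an aromatic carbon, is an at least 4.9-fold lower number from compound 1 to compound 2 (0.69 log units; beyond the scatter), and it rests on the limit of > 100000 nM in this assay, at which 1 of the 2 values shown sits, for compound 1.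

Compound 3 `O=c1ccoc2cc(OCc3cn(Cc4cccc(F)c4)nn3)ccc12` differs from compound 2 by fluoro in place of methyl on an aromatic carbon. Among the measured compounds shown here, no measured step swaps methyl for fluoro, so the expectation leans on the step from compound 1 to compound 2 alone, which shows that a group on this carbon can move the number, and on the small size of the change. A modest shift toward a higher number, possibly back toward the limit, is expected. The step from compound 2 to compound 3 is expected to be a 2.0-fold higher number from compound 2 to compound 3 (0.29 log units; within the scatter). Compound 3 is estimated at 40000 nM, with a range from 15000 nM to 120000 nM.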

Compound 3, half-maximal inhibitory concentration: > 100000 nM
Compound 3: a limit, no number; the forecaster's own chance of this, stated with the estimate: 30%; at least 2.5-fold (0.39 log units) between middle value and limit.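

In this assay a group on this carbon does not lower the number merely by being there: fluoro in place of methyl gives an at least 4.9-fold higher number from compound 2 to compound 3 (0.69 log units; beyond the scatter) and so undoes the effect seen with methyl in compound 2. Compound 3 sits at a limit of the assay, as compound 1 does, so the step between these two compounds cannot be read. Only compound 2 gives a number, and the other two compounds share one limit: the limit of > 100000 nM in this assay, at which 2 of the 3 values shown sit.

Among these compounds, whether methyl is the only group on this carbon that gives a number stays open, since ethyl, methoxy, chloro or trifluoromethyl could each read differently. An amine or a carboxylic acid in the same place would also show whether the number can fall further than it does for compound 2.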